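This account rests on a few compounds, and the source may have more. Where it says the series, first, only, none or still open, it means among the compounds named here.

Measured so far in an ADME assay on HepG2 cells (Homo sapiens) for cytotoxicity, read by luminescence, CellTiter-Glo and ATP content, with a stated time of 72 h; a lower number here means that less compound is needed, a higher number that more compound is needed for the effect:
compound 1 `Fc1ccc(Oc2ccc3c(NCCCNCc4ccco4)ccnc3c2)cc1` gives 16000 nM
compound 2 `CCC(CC)c1ccc2c(NCCCNCc3cccc(OC)c3O)ccnc2c1` gives 410 nM
compound 3 `Fc1ccc(Cc2ccc3c(NCCCNCc4ccco4)ccnc3c2)cc1` gives 5600 nM

Compound 3 stands second highest of the three numbers in this assay; compound 1 sits nearer to it than compound 2. Going by the values given here, the one measured step, a 2.9-fold lower number from compound 1 to compound 3 (0.46 log units; beyond the scatter), is the only single change on the shared core and it moved the number modestly. Compound 4 `CCC(CC)c1ccc2c(NCCCNCc3ccco3)ccnc2c1` differs from compound 3 by pentan-3-yl in place of 4-fluorobenzyl on an aromatic carbon. Among the compounds with values here, no measured step carries pentan-3-yl in place of 4-fluorobenzyl directly; compound 2, which already bears pentan-3-yl but a different amine portion, gives the lowest value of the three. A lower number for compound 4 than for compound 3 is therefore expected, a 3.7-fold lower number from compound 3 to compound 4 (0.57 log units; beyond the scatter). The scale of that expectation rests on what compound 2 gives, 410 nM. The estimate for compound 4 in this assay is 1500 nM, with a range from 500 nM to 5000 nM.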

Compound 4, half-maximal effective concentration: 6760 nM
For compound 4 the middle estimate is 4.5-fold (0.65 log units) below the measured one; the measured number lies above the stated range.
By their numbers in this assay, from the lowest: compound 2; then compounds 3 and 4 (each within the scatter of the next); then compound 1.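

In this assay, pentan-3-yl in place of 4-fluorobenzyl on the aromatic carbon leaves the number within the scatter (a 1.2-fold higher number from compound 3 to compound 4 (0.08 log units; within the scatter)), while the same group in place of 4-fluorophenoxy gives a modest step (a 2.4-fold lower number from compound 1 to compound 4 (0.37 log units; beyond the scatter)). Pentan-3-yl alone therefore does not reproduce the low number of compound 2; the large step comes with furan-2-yl in place of 2-hydroxy-3-methoxyphenyl in the amine portion (a 16-fold higher number from compound 2 to compound 4 (1.22 log units; beyond the scatter)). No measured evidence accounts for these steps.

As far as these compounds go, whether 2-hydroxy-3-methoxyphenyl gives a similar step alongside 4-fluorobenzyl or 4-fluorophenoxy remains open. So does the effect of a methyl group or a carboxylic acid on that aromatic carbon.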